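The compounds below may be only part of what the source reports. "The series", "measured", "known", "first", "only" and "open" are said of these compounds alone.

Three compounds have values in a functional assay on PANC-1 cells (Homo sapiens) for inhibition, read by MTT assay, with a stated time of 24 h (a higher number here means a weaker inhibitor, a lower number a stronger inhibitor), as follows

compound 1 `CC1(C)[C@H]2CC[C@]1(C)N(Cc1cn(-c3ccccc3C#N)nn1)C(=O)C2` gives 240 nM
compound 2 `CC1(C)[C@H]2CC[C@]1(C)N(Cc1cn(-c3ccccc3F)nn1)C(=O)C2` gives 150 nM
compound 3 `CC1(C)[C@H]2CC[C@]1(C)N(Cc1cn(-c3ccccc3Cl)nn1)C(=O)C2` gives 270 nM

Compound 3 stands within the scatter of both other compounds, with a 1.1-fold higher number from compound 1 to compound 3 (0.05 log units; within the scatter) and a 1.8-fold higher number from compound 2 to compound 3 (0.26 log units; within the scatter) as its two steps. Compound 4 `CC1(C)[C@H]2CC[C@]1(C)N(Cc1cn(-c3cccc(O)c3)nn1)C(=O)C2` carries 3-hydroxyphenyl in place of 2-chlorophenyl on an aromatic nitrogen and has not yet been measured. The nearest evidence comes from swaps of one group on an aromatic carbon. Besides those two steps there is a 1.6-fold lower number from compound 1 to compound 2 (0.20 log units; within the scatter) and all three lie within the scatter. Among the measured compounds shown here, none of the measured compounds carries a 3-hydroxyphenyl group, so these steps bear on the change only indirectly. No step beyond the scatter is therefore expected in this assay although the uncertainty is wide. The estimated change is a 1.1-fold lower number from compound 3 to compound 4 (0.03 log units; within the scatter) with no firm direction expected. For compound 4 the expected value is 250 nM with an estimated range from 80 nM to 800 nM as its likely span.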

Compound 4, half-maximal inhibitory concentration: 280 nM
For compound 4 the middle estimate is 1.1-fold (0.05 log units) below the measured one, within the range that was stated.
By their numbers in this assay, from the lowest: compounds 2, 1, 3 and 4 (each within the scatter of the next).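

In this assay, 3-hydroxyphenyl on the aromatic nitrogen stays within the scatter of all three earlier groups, with a 1.0-fold higher number from compound 3 to compound 4 (0.02 log units; within the scatter) and a 1.9-fold higher number from compound 2 to compound 4 (0.27 log units; within the scatter) and a 1.2-fold higher number from compound 1 to compound 4 (0.07 log units; within the scatter) as its steps. The earlier compounds shown here covered only 2-cyanophenyl, 2-fluorophenyl and 2-chlorophenyl, so compound 4 extends the comparison to a group with a different substitution pattern that also carries a hydrogen-bond donor and acceptor, and no step beyond the scatter accompanies the change. No measurement at hand accounts for this result.

Because both the substituent and its ring position differ in compound 4, the compounds shown cannot separate the two, and 2-hydroxyphenyl or 3-chlorophenyl would be needed to do so. On these data alone, it also remains open whether an amine or a carboxylic acid on the phenyl ring would stay within the scatter.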